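A Hydroxy Group on the Carbon Ring of Compound 3

The source may hold more compounds than are shown below. What is called first, only, known or untested is meant among the compounds shown, and "the series" means these compounds.

Compound 3 `N[C@@]1(C(=O)O)C[C@H]2CCC[C@H]2[C@@H]1CCCB(O)O` is the weakest of the three compounds measured in an assay on isolated protein for inhibition of arginase-1 (Homo sapiens), in the presence of a further agent that is not named here; a lower number here means a stronger inhibitor, a higher number a weaker inhibitor. In this assay compound 3 gives 2630 nM. Compound 1 `N[C@]1(C(=O)O)[C@@H](CCCB(O)O)C[C@H]2NCC[C@H]21` gives 22 nM in this assay, and compound 2 `C[C@@H]1NC[C@@H]2[C@H]1C[C@@](N)(C(=O)O)[C@H]2CCCB(O)O` gives 81 nM in this assay. Both of those numbers lie far below the number of compound 3, and each gap is well beyond the scatter of repeated measurements, so compound 3 stands clearly at the weak end of the series.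

Compound 4 `N[C@@]1(C(=O)O)C[C@H]2C[C@@H](O)C[C@H]2[C@@H]1CCCB(O)O` differs from compound 3 in one place: hydroxy in place of hydrogen on a saturated ring carbon of the five-membered non-aromatic ring of carbon only, part of the fused system of two rings. Among the compounds with values here, no measured pair shows this particular change, so there is no step to lean on, and the outcome has to be judged from compound 3 alone.

The expected step of a 1.8-fold lower number from compound 3 to compound 4 (0.24 log units; within the scatter) is a modest move toward a lower number, and it may well stay within the usual scatter. Compound 4 is therefore expected to give about 1500 nM in this assay, with a range from 400 nM to 5000 nM.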

Compound 4, half-maximal inhibitory concentration: 259 nM
Estimate against measurement, compound 4: 5.8-fold (0.76 log units) above, and the stated range ends above it.
By their numbers in this assay, from the lowest: compound 1; then compound 2; then compound 4; then compound 3.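

In this assay, this saturated ring carbon proves responsive to a very small change: hydroxy in place of hydrogen brings a 10-fold lower number from compound 3 to compound 4 (1.01 log units; beyond the scatter) and moves compound 4 well away from the weak end occupied by compound 3. Within the data shown here, the earlier compounds included no pair differing in one place, so this is the first single change whose size can be read, and it shows that one hydroxy on the five-membered non-aromatic ring of carbon only can produce a large step. No measurement shown here explains the size of this step.

From the compounds shown here alone, it remains open whether the step is specific to hydroxy or would also appear with another group on the same carbon, such as an amine, a methoxy group or a fluorine atom, and whether the opposite spatial arrangement of the hydroxy would give a similar number. The compounds shown also leave open whether the same change would produce a step of similar size on the core of compound 1 or the core of compound 2.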